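Methoxy in place of methyl on compound 1

This account rests on a few compounds, and the source may have more. Where it says the series, first, only, none or still open, it means among the compounds named here.

Measured in an ADME assay on microsomes from liver (Homo sapiens) for metabolic stability; on this read-out lower numbers stand for slow clearance and higher numbers for fast clearance:
Compound 1 `Cc1cc(Cl)ccc1-c1ccc(N2CCc3c(C)ccc(N4CCN(C)CC4)c3C2)nc1`: 0.022 mL/min/kg
Compound 2 `Cc1ccc(N2CCN(C)CC2)c2c1CCN(c1ccc(-c3ccc(C(C)(C)C)cc3)cn1)C2`: 0.041 mL/min/kg

Within the data shown here, compound 1 stands level with the only other measured compound, since the two values lie within the scatter of each other. Compound 3 `COc1ccc(N2CCN(C)CC2)c2c1CCN(c1ccc(-c3ccc(Cl)cc3C)cn1)C2` keeps the rest of compound 1 and carries methoxy in place of methyl on an aromatic carbon, para to a 4-methylpiperazin-1-yl group (methoxy in place of methyl on an aromatic carbon).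

Among the measured compounds shown here, only one measured step exists, a 1.9-fold higher number from compound 1 to compound 2 (0.27 log units; within the scatter), and it swaps 4-chloro-2-methylphenyl for 4-(tert-butyl)phenyl at another site. For the measured compounds named here, it therefore bears only indirectly, and no measured step shows what this change does. No step beyond the scatter is expected in this assay, and the data give no direction. The expected step is a 1.3-fold higher number from compound 1 to compound 3 (0.10 log units; within the scatter). For compound 3 the estimated value is 0.028 mL/min/kg, with an expected range from 0.012 mL/min/kg to 0.065 mL/min/kg.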

Compound 3, clearance: 0.017 mL/min/kg
Compound 3: middle estimate off by 1.6-fold (0.22 log units), on the high side, within the range that was stated.
By their numbers in this assay, from the lowest: compounds 3, 1 and 2 (each within the scatter of the next, the first and the last beyond it).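

In this assay, among these compounds, the first measured swap at this position, methoxy in place of methyl on an aromatic carbon para to a 4-methylpiperazin-1-yl group, gives a 1.3-fold lower number from compound 1 to compound 3 (0.11 log units; within the scatter) for the pair. The position thus takes methoxy, with its oxygen and its hydrogen-bond acceptor, and the two compounds stand level, so this pair does not tell the two groups apart. No separate measurement offers an account of this outcome.

Going by these compounds, the pair covers only methyl and methoxy, so it remains open whether an amine, a carboxylic acid or a longer chain on this carbon would also stay level with compound 1. On these data alone, it is equally open whether methoxy would read the same with 4-(tert-butyl)phenyl in place of 4-chloro-2-methylphenyl on the other side of the molecule.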